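The source may report more compounds than this note shows. Statements on the series, on what has been measured and on what is new or still open speak of the compounds shown alone.

Measured compounds:
compound 1 `Brc1cncc(N2CC[C@@H]3CN[C@@H]3C2)c1` gives 950 nM;
compound 2 `N#Cc1cncc(N2CC[C@@H]3CN[C@@H]3C2)c1` gives 490 nM;
compound 3 `COc1cncc(N2CC[C@H]3CN[C@H]3C2)c1` gives 180 nM.

In a functional assay on HEK293 cells for agonist activity at Neuronal acetylcholine receptor; alpha3/beta4 (Homo sapiens), read by FLIPR (a higher number here means that more compound is needed for the effect, a lower number that less compound is needed), compound 3 stands at the lowest of the three numbers; compound 2 lies a clear step above it and compound 1 further still. Going by the values given here, the only step between measured compounds, a 1.9-fold lower number from compound 1 to compound 2 (0.29 log units; within the scatter), is a change of substituent and says nothing about configuration. Compound 4 `COc1cncc(N2CC[C@@H]3CN[C@@H]3C2)c1` is the mirror image of compound 3: the two compounds have the same atoms and bonds and differ only in configuration as drawn: 2 of 2 stereo elements differ (all stereocentres are inverted: mirror images); a stereocentre at a saturated ring carbon is drawn S in compound 3 and R in compound 4; a stereocentre at a saturated ring carbon is drawn R in compound 3 and S in compound 4. Among the compounds with values here, no measured pair shows what such an inversion does here, so the direction is open; compounds 1 and 2 carry the configuration drawn for compound 4 but other substituents. Compound 4 is therefore expected to give about 600 nM, within 150 nM to 2500 nM, the step of a 3.3-fold higher number from compound 3 to compound 4 (0.52 log units; beyond the scatter) being an estimate of wide uncertainty.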

Compound 4, half-maximal effective concentration: 4500 nM
Estimate against measurement, compound 4: 7.5-fold (0.88 log units) below; the whole stated range lies below it.
By their numbers in this assay, from the lowest: compound 3; then compounds 2 and 1 (each within the scatter of the next); then compound 4.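

In this assay, the configuration of the shared core proves to matter strongly, with a 25-fold higher number from compound 3 to compound 4 (1.40 log units; beyond the scatter), and this step can be put down to configuration alone because of one fact: the fact that compounds 3 and 4 differ only in the configuration as drawn Within the configuration drawn for compound 4, the substituent matters too, with a 9.2-fold higher number from compound 2 to compound 4 (0.96 log units; beyond the scatter) and a 4.7-fold higher number from compound 1 to compound 4 (0.68 log units; beyond the scatter). Methoxy therefore gives the highest number of these three substituents in that configuration, not the lowest.

The compounds shown leave open whether inversion has a similar effect with bromo or cyano in place of methoxy. They also leave open how an amine or a longer alkoxy chain would behave in either configuration.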